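A few compounds are considered here, and "the series" means these few. Any claim that something is new, unique, unknown or untested is made for them only; others in the source may bear on it.

Compound 3, `CCNC(=S)N1N=C(c2ccc(OC)cc2)CC1c1ccc[nH]1`, gives the highest of the three numbers measured in a functional assay on the whole organism (strain Swiss Albino) for inhibition, with Mus musculus as the target, at a dose of 100 mg/kg by the oral route; a higher number here means more inhibition at the dose given (going by the name of the read-out), a lower number less inhibition: compound 3 gives 56.6%. Compound 2, `CCCNC(=S)N1N=C(c2ccc(C)cc2)CC1c1ccc[nH]1`, gives 48.2%, which lies within the scatter of compound 3, while compound 1, `CCNC(=S)N1N=C(c2ccc(C)cc2)CC1c1ccc[nH]1`, gives 15.4%. Compound 4, `CCCNC(=S)N1N=C(c2ccc(OC)cc2)CC1c1ccc[nH]1`, differs from compound 3 by methyl in place of hydrogen on a saturated chain carbon, two bonds along the chain from an amide-type nitrogen. The same change has been measured once, going from compound 1 to compound 2, where a number 32.8 percentage points higher from compound 1 to compound 2 (beyond the scatter). The other step, a number 41.2 percentage points higher from compound 1 to compound 3 (beyond the scatter), swaps a group on the aromatic ring and does not bear on this change. A rise beyond the scatter is therefore expected, yet a smaller one, as the read-out has little room above the level of compound 3; the expected step is a number 15.4 percentage points higher from compound 3 to compound 4 (beyond the scatter). Compound 4 is estimated at 72%, with a range from 52% to 90%.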

Compound 4, a percentage reported as inhibition, in the whole organism at one dose (the size of the read-out at that dose, not a potency): 60%
Compound 4: the middle estimate sits 12 percentage points above what was measured; the range from low to high includes it.
By their numbers in this assay, from the lowest: compound 1; then compounds 2, 3 and 4 (each within the scatter of the next, the first and the last beyond it).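

In this assay, going from ethylamino to propylamino gives a number 3.4 percentage points higher from compound 3 to compound 4 (within the scatter), so where methoxy is present this change has no effect that stands out from the scatter. The gain from this change therefore depends on the group on the aromatic carbon: the same change on two cores in this assay, a number 32.8 percentage points higher (beyond the scatter) from compound 1 to compound 2 and a number 3.4 percentage points higher (within the scatter) from compound 3 to compound 4, 29.4 percentage points apart, beyond the scatter of two such steps Methoxy in place of methyl also gains less once propylamino is present, giving a number 11.8 percentage points higher from compound 2 to compound 4 (beyond the scatter): the same change on two cores in this assay, a number 41.2 percentage points higher (beyond the scatter) from compound 1 to compound 3 and a number 11.8 percentage points higher (beyond the scatter) from compound 2 to compound 4, 29.4 percentage points apart, beyond the scatter of two such steps The compounds shown leave open whether a longer chain, such as butyl, or a chain ending in an amine would change the number further.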